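The source may hold more compounds than are shown below. What is called first, only, known or untested is meant among the compounds shown, and "the series" means these compounds.

Three compounds that share a benzamide core bearing a dithiocarbamate arm have been tested in a functional assay on A-375 cells (Homo sapiens) for antiproliferative activity, read by CCK-8 assay, with a stated time of 72 h, tested at 2 uM; a lower number here means a weaker effect, a higher number a stronger effect of the compound at the concentration tested. Compound 1, `Nc1ccccc1NC(=O)c1ccc(CSC(=S)N2CCN(Cc3ccncc3)CC2)cc1`, gives 33.1%. Compound 2, `Nc1ccccc1NC(=O)c1ccc(CSC(=S)N2CCN(Cc3cccnc3)CC2)cc1`, gives 31.5%. The two differ in one place, and the step from one to the other is a number 1.6 percentage points lower from compound 1 to compound 2 (within the scatter); that change is pyridin-3-yl in place of pyridin-4-yl on a saturated chain carbon bound to an amine nitrogen in a ring. Compound 3, `CN(Cc1ccncc1)C(=S)SCc1ccc(C(=O)Nc2ccccc2N)cc1`, gives 31.4%. Its value sits within the scatter of both compound 2 and compound 1, so the three numbers cannot be told apart. The difference between the core of compound 3 and the core of compound 1 is not broken down here.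

Compound 4, `CN(Cc1cccnc1)C(=S)SCc1ccc(C(=O)Nc2ccccc2N)cc1`, has not yet been measured. It differs from compound 3 by pyridin-3-yl in place of pyridin-4-yl on a saturated chain carbon bound to an amide-type nitrogen. Within the data shown here, this is the same kind of change as the one made from compound 1 to compound 2, though the place is not the same: there the saturated chain carbon is bound to an amine nitrogen in a ring, here to an amide-type nitrogen. Among the measured compounds shown here, the step from compound 3 to compound 4 is expected to be a number 1.4 percentage points lower from compound 3 to compound 4 (within the scatter), because the one measured example of this kind of change, a number 1.6 percentage points lower from compound 1 to compound 2 (within the scatter), stayed within the scatter. Compound 4 is therefore estimated to give 30%, with a likely range from 20% to 40%.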

Compound 4, a percentage reported as inhibition, at one concentration (the size of the read-out at that concentration, not a potency): 39.4%
The estimate for compound 4 lay 9.4 percentage points below the measured number, within the range that was stated.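

Pyridin-3-yl in place of pyridin-4-yl has now been read on two cores in this assay, and on the core of compound 3 the step is a number 8 percentage points higher from compound 3 to compound 4 (within the scatter). Set beside the earlier step, this one cannot be told apart from it: the same change on two cores in this assay, a number 1.6 percentage points lower (within the scatter) from compound 1 to compound 2 and a number 8 percentage points higher (within the scatter) from compound 3 to compound 4, 9.6 percentage points apart, within the scatter of two such steps. So, as far as these two pairs go, the change carries from one core to the other without a difference that the measurements can detect, and on neither core does it lead to a step beyond the usual scatter; what this does not show is that the two cores truly respond alike, as each core offers only one pair, and a read-out at one concentration gives no potency, so a real but modest difference could remain hidden in the scatter.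

All four compounds shown carry either pyridin-3-yl or pyridin-4-yl on the saturated chain carbon, which leaves open how pyridin-2-yl or a plain phenyl ring would behave in that place. Also open, on these data alone, is whether the picture would hold with an ethyl group in place of the methyl group on the nitrogen of compound 3 and compound 4, or with a longer chain carrying the ring.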